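Benzamide hexanoic acids: cytotoxicity notes ahead of compound 4

The compounds below may be only part of what the source reports. "The series", "measured", "known", "first", "only" and "open" are said of these compounds alone.

Compound 1 `CC(C)N(Cc1cccc(OCCCCCC(=O)O)c1)C(=O)c1ccccc1` in an ADME assay on HepG2 cells (Homo sapiens) for cytotoxicity, read by CellTiter-Glo and resazurin assay, with a stated time of 72 h; a lower number here means that less compound is needed, a higher number that more compound is needed for the effect: > 26000 nM, a limit of the assay.
Compound 2 `CC(C)N(Cc1cccc(OCCCCCC(=O)O)c1)C(=O)c1ccc(-c2cccc(-c3ccccc3)c2)cc1` in this assay: > 26000 nM, a limit of the assay.
Compound 3 `COc1cccc(-c2ccc(C(=O)N(Cc3cccc(OCCCCCC(=O)O)c3)C(C)C)cc2)c1` in this assay: > 26000 nM, a limit of the assay.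

Compound 3 stands at the limit of this assay, and the two other values shown sit at the same limit, so no ranking among the three compounds can be read. The three steps between them are therefore unreadable: a step that the two limits leave unreadable from compound 1 to compound 2, a step that the two limits leave unreadable from compound 1 to compound 3 and a step that the two limits leave unreadable from compound 2 to compound 3. All that the numbers say is summed up by the limit of > 26000 nM in this assay, at which 3 of the 3 values shown sit.

Compound 4 `CC(C)N(Cc1cccc(OCCCCCC(=O)O)c1)C(=O)c1ccc(-c2cccc(OC(F)(F)F)c2)cc1` differs from compound 3 by trifluoromethyl in place of methyl on an oxygen on an aromatic ring. None of the three measured steps is readable in size, so none gives a direction for this change; what they do show is that neither the bare benzamide of compound 1, the 3-phenylphenyl group of compound 2 nor the 3-methoxyphenyl group of compound 3 produced a measurable effect in this assay. With no readable step to build on, the expected step is a step that the limit leaves unreadable from compound 3 to compound 4, and it is most likely that compound 4 also returns only a limit. Compound 4 is estimated at 40000 nM, with a range from 15000 nM to 120000 nM.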

Compound 4, half-maximal effective concentration: > 26000 nM
Compound 4 was reported as a limit (the forecaster's own chance of this, stated with the estimate: 80%); the middle value does not contradict the limit.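

In this assay compound 4 gives > 26000 nM, a limit of the assay. Its steps to compound 1, compound 2 and compound 3 therefore cannot be read in size: the limit of > 26000 nM in this assay, at which 4 of the 4 values shown sit.

The compounds shown leave open whether any member of this series has a measurable effect in this assay, and at what concentration.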